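Removing the trifluoromethyl group from compound 1

This account rests on a few compounds, and the source may have more. Where it says the series, first, only, none or still open, it means among the compounds named here.

In an ADME assay on the whole organism (Mus musculus, strain ICR) for metabolic stability, read by HPLC, with a stated time of 24 h, at a dose of 50 mg/kg by the oral route (on this read-out higher numbers stand for a longer-lived compound and lower numbers for a shorter-lived compound), compound 1 `CCc1nc2ccc(Br)cn2c1C(=O)NCCOc1ccc(N2CCC(C(F)(F)F)CC2)cc1` gives 4.71 h. Compound 2 `CCc1nc2ccc(Cl)cn2c1C(=O)NCCOc1ccc(N2CCN(c3ccc(F)cc3)CC2)cc1` gives 4.41 h, level with compound 1 within the scatter. Compound 3 `COc1ccc2nc(C)c(C(=O)NCCOc3ccc(N4CCC(C(F)(F)F)CC4)cc3)n2c1` gives 0.916 h and so stands clearly lower than both. Compound 1 therefore belongs to the upper pair of this small set.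

Compound 4 `CCc1nc2ccc(Br)cn2c1C(=O)NCCOc1ccc(N2CCCCC2)cc1` differs from compound 1 in one place: hydrogen in place of trifluoromethyl on a saturated ring carbon. Hydrogen takes the place of trifluoromethyl on a saturated ring carbon, so 4-(trifluoromethyl)piperidin-1-yl becomes piperidin-1-yl.

For the measured compounds named here, no measured pair isolates this change. Compound 1 and compound 3 carry the same 4-(trifluoromethyl)piperidin-1-yl group, yet compound 3 gives 0.916 h, while compound 2 lacks it and gives 4.41 h. These compounds also differ elsewhere, so they do not tie the half-life to that group, and only a modest fall close to the usual scatter is expected. The expected step is estimated as a 1.9-fold lower number from compound 1 to compound 4 (0.28 log units; within the scatter). Compound 4 is expected to give 2.5 h, with an estimated range from 0.9 h to 6 h.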

Compound 4, half-life: 4.19 h
For compound 4 the middle estimate is 1.7-fold (0.22 log units) below the measured one; the measured number falls inside the stated range.
By their numbers in this assay, from the lowest: compound 3; then compounds 4, 2 and 1 (each within the scatter of the next).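

In this assay, hydrogen in place of trifluoromethyl on a saturated ring carbon gives a 1.1-fold lower number from compound 1 to compound 4 (0.05 log units; within the scatter). This is the first pair shown that differs in this one place alone, and it shows that, on the core of compound 1, the half-life with piperidin-1-yl stands level with that of 4-(trifluoromethyl)piperidin-1-yl, so the trifluoromethyl group is not needed there to hold the number in the upper group of the set. No measurement shown explains why the two stand level.

Going by these compounds, whether the same swap stays level on another core, such as that of compound 3, remains open, as this single pair speaks only for the core of compound 1. Also open, on these data alone, is how a hydroxyl group, a carboxylic acid or a primary amine on the same ring carbon would read in this assay.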